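Naphthalenyl in place of methoxypyridinyl on a shared core

This account rests on a few compounds, and the source may have more. Where it says the series, first, only, none or still open, it means among the compounds named here.

Measured compounds:
compound 1 `CNc1cc(C(N)=O)ccc1-n1nc(C(C)C)c2c(-n3cnc(-c4cnn(C)c4)c3)ccnc21`, 419 nM
compound 2 `CNc1cc(-n2nc(C(C)C)c3c(-n4cnc(-c5cnn(C)c5)c4)ccnc32)ccc1C(N)=O`, 773 nM
compound 3 `COc1cncc(-c2ccnc3c2c(C(C)C)nn3-c2ccc(C(N)=O)c(N[C@H]3CC[C@H](O)CC3)c2)c1`, 451 nM

In a functional assay on SK-BR-3 cells (Homo sapiens) for inhibition, read by CellTiter-Glo, with a stated time of 72 h (a lower number here means a stronger inhibitor, a higher number a weaker inhibitor), compound 3 gives 451 nM, a number that sits in the middle of the three, with compound 1 nearest and compound 2 furthest, both gaps within the usual scatter. Compound 4 `CC(C)c1nn(-c2ccc(C(N)=O)c(N[C@H]3CC[C@H](O)CC3)c2)c2nccc(-c3ccc4ccccc4c3)c12` is made from compound 3 by one change: naphthalen-2-yl in place of 5-methoxypyridin-3-yl on an aromatic carbon. For the measured compounds named here, the only measured step, a 1.8-fold higher number from compound 1 to compound 2 (0.27 log units; within the scatter), concerns the group on the aromatic nitrogen, not the group on this aromatic carbon, so it does not bear on the change from compound 3 to compound 4. Going by the values given here, no measured pair in this set varies the group at this position, so the direction of the step cannot be read from the data. Compound 4 is therefore expected to stay close to compound 3 in this assay, with the step of a 1.3-fold higher number from compound 3 to compound 4 (0.12 log units; within the scatter) estimated as small and of uncertain direction. The estimate for compound 4 is 600 nM, within the range 150 nM to 2500 nM.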

Compound 4, half-maximal inhibitory concentration: > 10000 nM
Compound 4 gave a limit, no number (the forecaster's own chance of this, stated with the estimate: 5%); middle value at least 16-fold (1.22 log units) away from the limit.
By their numbers in this assay, from the lowest: compounds 1, 3 and 2 (each within the scatter of the next). At a limit, above all of these: compound 4.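

In this assay, compound 4 reads only as a limit, > 10000 nM, and not as a number: the limit of > 10000 nM in this assay, at which 1 of the 4 values shown sits. Naphthalen-2-yl in place of 5-methoxypyridin-3-yl on this aromatic carbon gives an at least 22-fold higher number from compound 3 to compound 4 (1.34 log units; beyond the scatter), the first step at this position and one beyond the scatter. This place on the shared core therefore does not accept every aromatic group in this assay: the entering group, with two six-membered aromatic rings of carbon only and no hydrogen-bond acceptors, loses the activity seen with the leaving group.

From the compounds shown here alone, whether the second fused ring or the loss of the ring nitrogen and methoxy oxygen matters more stays open, as a single pair cannot separate them. Going by these compounds, a plain phenyl, a pyridinyl without the methoxy or a quinolinyl at this place would address that, and the true size of the step also remains unknown.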